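Chloro in Place of Methoxy: What to Expect of Compound 4

A few compounds are considered here, and "the series" means these few. Any claim that something is new, unique, unknown or untested is made for them only; others in the source may bear on it.

Measured so far:
compound 1 `COc1ccc2[nH]c(-c3cccc(C)n3)nc2c1`: 40%
compound 2 `Cc1cccc(-c2nc3cc(Cl)ccc3[nH]2)n1`: 39%
compound 3 `CCc1cccc(-c2nc3cc(OC)ccc3[nH]2)n1`: 52%

All three were tested in a functional assay on the whole organism with Rattus norvegicus as the target, read by paw edema, with a stated time of 3 h, at a dose of 100 mg/kg by the oral route; a higher number here means more inhibition at the dose given (going by the name of the read-out), a lower number less inhibition. Two single changes connect them. The first, (chloro in place of methoxy on an aromatic carbon), gives a number 1 percentage points lower from compound 1 to compound 2 (within the scatter), so the two values cannot be told apart. The second, (methyl in place of hydrogen on a saturated chain carbon bound to an aromatic carbon), gives a number 12 percentage points higher from compound 1 to compound 3 (beyond the scatter), and compound 3 stands highest of the three, its steps to compound 1 and compound 2 both beyond the scatter.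

Compound 4 `CCc1cccc(-c2nc3cc(Cl)ccc3[nH]2)n1` has not been measured. It differs from compound 3 by chloro in place of methoxy on an aromatic carbon, the same change already seen between compound 1 and compound 2, at a place described in identical words. Since that earlier step was a number 1 percentage points lower from compound 1 to compound 2 (within the scatter), a similar step is expected here, a number 1 percentage points lower from compound 3 to compound 4 (within the scatter), resting on that one pair alone. Compound 4 is therefore estimated at 51%, most likely between 38% and 63%.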

Compound 4, a percentage reported as inhibition, in the whole organism at one dose (the size of the read-out at that dose, not a potency): 3%
The estimate for compound 4 lay 48 percentage points above the measured number; measured number below the stated range.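

Chloro in place of methoxy did not carry over from the core of compound 1 to the core of compound 3, where this assay gives a number 49 percentage points lower from compound 3 to compound 4 (beyond the scatter): the same change on two cores in this assay, a number 1 percentage points lower (within the scatter) from compound 1 to compound 2 and a number 49 percentage points lower (beyond the scatter) from compound 3 to compound 4, 48 percentage points apart, beyond the scatter of two such steps

Methyl in place of hydrogen on the saturated chain carbon did not carry over either, giving a number 36 percentage points lower from compound 2 to compound 4 (beyond the scatter): the same change on two cores in this assay, a number 12 percentage points higher (beyond the scatter) from compound 1 to compound 3 and a number 36 percentage points lower (beyond the scatter) from compound 2 to compound 4, 48 percentage points apart, beyond the scatter of two such steps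

Both gaps come from the same four compounds, so they are a single finding seen from two sides: in this small set the two changes do not simply add up, and a step measured on one core cannot safely be moved to the other, but nothing here shows why, or how any other core would behave.

The compounds shown leave open whether this sharp drop belongs to chloro specifically or would also appear with another group in its place, such as fluoro or hydroxy. They also leave open what a longer chain, such as propyl, would do in the presence of chloro or methoxy.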